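Swapping a Thioester for an Ethoxymethyl Group

The compounds below may be only part of what the source reports. "The series", "measured", "known", "first", "only" and "open" are said of these compounds alone.

Of the compounds shown here, three built on one shared core have been tested in a functional assay on KB cells (Homo sapiens) for cytotoxicity, read by MTT assay, with a stated time of 72 h; on this read-out higher numbers stand for an effect only at larger amounts of compound and lower numbers for an effect already at smaller amounts. Compound 1 `CCOc1c(-c2occ(C)c2C(=O)O)ccc2c(CC)cccc12`, with a free carboxylic acid, gives > 10 ug/mL, which is a limit of the assay rather than a number. Its methyl ester, compound 3 `CCOc1c(-c2occ(C)c2C(=O)OC)ccc2c(CC)cccc12`, gives 1.8 ug/mL, so that an at least 5.5-fold lower number from compound 1 to compound 3 (0.74 log units; beyond the scatter). Compound 2 `CCc1cccc2c(OC)c(-c3occ(C)c3C(=S)OC)ccc12`, carrying a methyl thioester, gives 4.3 ug/mL, the higher of the two numbers; its nearest neighbour, compound 3, sits lower by a gap beyond the usual scatter.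

Compound 4 `CCOCc1c(C)coc1-c1ccc2c(CC)cccc2c1OC` differs from compound 2 in one place: a group of 4 heavy atoms (3 carbon, 1 oxygen; no ring) in place of a group of 4 heavy atoms (2 carbon, 1 oxygen, 1 sulfur; no ring), on an aromatic carbon. Among the compounds with values here, no measured step touches this change, since the only one, an at least 5.5-fold lower number from compound 1 to compound 3 (0.74 log units; beyond the scatter), concerns the oxygen of an ester. The expectation is therefore a value near compound 2, estimated at 6 ug/mL (range 2 ug/mL to 20 ug/mL), that is a 1.4-fold higher number from compound 2 to compound 4 (0.14 log units; within the scatter).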

Compound 4, concentration for half-maximal effect: > 10 ug/mL
Compound 4 ended at the assay's limit; the forecaster's own chance of this, stated with the estimate: 25%; middle value at least 1.6-fold (0.22 log units) from the limit.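

In this assay, ethoxymethyl in place of the sulfur-containing group gives an at least 2.3-fold higher number from compound 2 to compound 4 (0.36 log units; beyond the scatter). This is the first change shown to the whole group at this position, and it shows that two groups of 4 heavy atoms need not read alike here. Compound 4 gives a limit of the assay, not a number, so the full size of the step stays unknown: the limit of > 10 ug/mL in this assay, at which 2 of the 4 values shown sit.

Still open, as far as these compounds go, is whether the sulfur or the double bond outside aromatic rings matters more. An amide or a methoxymethyl group at this position could help to separate the two.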